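Series notes: carboxy to hydroxymethyl on the side chain

A few compounds are considered here, and "the series" means these few. Any claim that something is new, unique, unknown or untested is made for them only; others in the source may bear on it.

Measured so far in a functional assay on HEK293 cells for agonist activity at Bile acid receptor (Homo sapiens); a higher number here means a larger maximal response, a lower number a smaller maximal response:
- compound 1, `CC(C)c1onc(-c2c(Cl)cccc2Cl)c1COc1ccc(N(C)Cc2ccc(CCC(=O)O)cc2)c(C(F)(F)F)n1`, gives 55%
- compound 2, `CC(C)c1onc(-c2c(Cl)cccc2Cl)c1COc1ccc(N(C)Cc2cccc(C(=O)O)c2)c(C(F)(F)F)n1`, gives 89%
- compound 3, `CC(C)c1onc(-c2c(Cl)cccc2Cl)c1COc1ccc(N(C)Cc2ccc(OCC(=O)O)cc2)c(C(F)(F)F)n1`, gives 69%

Compound 3 stands second highest of the three numbers: it sits above compound 1 by a number 14 percentage points higher from compound 1 to compound 3 (beyond the scatter) and below compound 2 by a number 20 percentage points lower from compound 2 to compound 3 (beyond the scatter), both beyond the scatter. The largest move in the set is a number 34 percentage points higher from compound 1 to compound 2 (beyond the scatter).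

Compound 4, `CC(C)c1onc(-c2c(Cl)cccc2Cl)c1COc1ccc(N(C)Cc2ccc(OCCO)cc2)c(C(F)(F)F)n1`, is the next member. Relative to compound 3 the change is hydroxymethyl in place of carboxy on a saturated chain carbon bound to an oxygen on an aromatic ring.

None of the three measured steps bears directly on this change. Each of them moves a carboxy group from one position or chain to another while keeping it; none removes the acid group or replaces it with an alcohol. The steps do show that the part of the molecule carrying the acid is sensitive to alteration, with moves of modest to large size in this assay, so a step beyond the scatter in either direction is plausible, but its sign is not settled by the data.

Compound 4 is therefore estimated at 55%, within 30% to 85%. The expected step is a number 14 percentage points lower from compound 3 to compound 4 (beyond the scatter), with wide uncertainty.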

Compound 4, largest response reached (reported as efficacy), in percent of the reference or control that the assay uses: 43%
Compound 4: the middle estimate sits 12 percentage points above what was measured; the range from low to high includes it.
By their numbers in this assay, from the lowest: compound 4; then compound 1; then compound 3; then compound 2.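

Among these compounds, exchanging carboxy for hydroxymethyl on this saturated chain carbon bound to an oxygen on an aromatic ring is the first change that removes the carboxy group rather than relocating it, and in this assay it gives a number 26 percentage points lower from compound 3 to compound 4 (beyond the scatter) while leaving a clear response in place. The 4-(2-hydroxyethoxy)phenyl compound also falls short of both other carboxy compounds, with a number 46 percentage points lower from compound 2 to compound 4 (beyond the scatter) and a number 12 percentage points lower from compound 1 to compound 4 (beyond the scatter), so compound 4 is the lowest of the four and all three compounds that keep a carboxy group stand above it, with none going against this. No supporting measurement is available to explain this drop.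

As far as these compounds go, what remains open is whether the loss belongs to the carboxy group itself or to this one chain, since the same exchange on the 3-carboxyphenyl of compound 2 or the 2-carboxyethyl of compound 1 could give a step of a different size. A primary amide or a methyl ether at this chain end would help separate these readings, as would a tetrazole in place of the carboxy group.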